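The compounds below may be only part of what the source reports. "The series", "measured", "known", "first", "only" and "open" are said of these compounds alone.

Measured compounds in this series:
compound 1 `COc1ccc(C(=O)c2sc(Nc3ccccc3)nc2N)cc1OC` — 6000 nM
compound 2 `Nc1nc(Nc2ccc(F)cc2)sc1C(=O)c1ccccc1` — > 10000 nM, a limit
compound 3 `COc1cccc(Nc2nc(N)c(C(=O)c3ccccc3)s2)c1` — 3200 nM

All values come from a functional assay on HeLa cells (Homo sapiens) for antiproliferative activity, read by cell counting, with a stated time of 2 days; a lower number here means a stronger inhibitor, a higher number a weaker inhibitor. Of the two numbers that are numbers, compound 1 gives the higher one with 6000 nM, while compound 3 sits at 3200 nM; the gap between them is within the usual scatter, so no order between compound 1 and compound 3 can be read from it. Compound 2 reaches only a limit of the assay, > 10000 nM, and gives no number; of the three values, one sits at that limit (the limit of > 10000 nM in this assay, at which 1 of the 3 values shown sits).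

Among the measured compounds shown here, no two measured compounds differ in only one place, so no measured step is available as a guide for the next compound. Compound 4 `COc1cccc(C(=O)c2sc(Nc3ccccc3)nc2N)c1` differs from compound 1 by hydrogen in place of methoxy on an aromatic carbon. For the measured compounds named here, with no comparable step on record, the expectation for this change in this assay is a step of no size beyond the scatter, in neither direction. Compound 4 is therefore expected to fall near compound 1, with an estimate of 5500 nM between 2000 nM and 15000 nM. The expected step from compound 1 to compound 4 is a 1.1-fold lower number from compound 1 to compound 4 (0.04 log units; within the scatter).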

Compound 4, half-maximal inhibitory concentration: 1700 nM
For compound 4 the middle estimate is 3.2-fold (0.51 log units) above the measured one, outside the stated range (below it).
By their numbers in this assay, from the lowest: compounds 4, 3 and 1 (each within the scatter of the next, the first and the last beyond it). At a limit, above all of these: compound 2.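

In this assay, hydrogen in place of methoxy, on an aromatic carbon ortho to a methoxy group and para to a large group, gives a 3.5-fold lower number from compound 1 to compound 4 (0.55 log units; beyond the scatter). Among the compounds shown here, this is the first one-place change measured, and it shows that this methoxy is not required for the antiproliferative activity: the number falls beyond the scatter once it is gone, with the second methoxy of compound 1 still in place. No measured property bears on this step, and the data offer no explanation for it.

From the compounds shown here alone, whether the methoxy that remains in compound 4 can also be replaced by hydrogen stays open. Equally open, going by these compounds, is how an amine, a hydroxyl or a longer alkoxy chain on this same aromatic carbon would compare with hydrogen and methoxy.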